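One Carbon More on a Hydroxamate Chain

The source may hold more compounds than are shown below. What is called first, only, known or untested is meant among the compounds shown, and "the series" means these compounds.

Compound 1 `O=C(CCCCCn1cc(Nc2ncc3ccn(Cc4cccc(Cl)c4)c3n2)cn1)NO` gives 34.4 nM in an assay on isolated protein for inhibition of protein deacetylase HDAC6 (Homo sapiens), with a stated time of 60 min; on this read-out lower numbers stand for stronger inhibition and higher numbers for weaker inhibition.
Compound 2 `O=C(CCCCCCn1cc(Nc2ncc3ccn(Cc4cccc(Cl)c4)c3n2)cn1)NO` gives 36.8 nM.
Compound 3 `COc1cccc(Cn2ccc3cnc(Nc4cnn(CCCCCC(=O)NO)c4)nc32)c1` gives 37.6 nM.

All three share one core and carry a chain ending in a hydroxamic acid, the group that is read out here. Compound 2 differs from compound 1 by (hydroxycarbamoyl)methyl in place of hydroxycarbamoyl on a saturated chain carbon, five bonds along the chain from an aromatic nitrogen. That change gave a 1.1-fold higher number from compound 1 to compound 2 (0.03 log units; within the scatter), so lengthening the chain by one carbon left the number essentially where it was. Compound 3 differs from compound 1 by methoxy in place of chloro on an aromatic carbon, and that change gave a 1.1-fold higher number from compound 1 to compound 3 (0.04 log units; within the scatter), again within the usual spread of repeat measurements. None of the three can be called stronger or weaker than another on these numbers.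

Compound 4 `COc1cccc(Cn2ccc3cnc(Nc4cnn(CCCCCCC(=O)NO)c4)nc32)c1` has not been measured. It differs from compound 3 by (hydroxycarbamoyl)methyl in place of hydroxycarbamoyl on a saturated chain carbon, five bonds along the chain from an aromatic nitrogen. Among the compounds with values here, this is the same change as the one that leads from compound 1 to compound 2, made at the same place on the chain; the two cores differ only by methoxy in place of chloro on an aromatic carbon. Within the data shown here, the one earlier example of this change gave a 1.1-fold higher number from compound 1 to compound 2 (0.03 log units; within the scatter), so the step is expected to be small: a 1.1-fold higher number from compound 3 to compound 4 (0.03 log units; within the scatter). Among the measured compounds shown here, with only one precedent, a wider spread is allowed for. Compound 4 is therefore expected to give about 40 nM, most likely between 20 nM and 80 nM.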

Compound 4, half-maximal inhibitory concentration: 28.8 nM
Compound 4: the middle estimate sits 1.4-fold (0.14 log units) above what was measured; the range from low to high includes it.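

In this assay, adding one carbon to the chain on the methoxy core gave a 1.3-fold lower number from compound 3 to compound 4 (0.12 log units; within the scatter), and putting methoxy in place of chloro on the longer chain gave a 1.3-fold lower number from compound 2 to compound 4 (0.11 log units; within the scatter). The chain step carries over from the chloro core to the methoxy core as a small step, and the two examples do not differ by more than repeat measurements usually do: the same change on two cores in this assay, a 1.1-fold higher number (0.03 log units; within the scatter) from compound 1 to compound 2 and a 1.3-fold lower number (0.12 log units; within the scatter) from compound 3 to compound 4, 1.4-fold (0.15 log units) apart, within the scatter of two such steps. Within the data shown here, the methoxy-for-chloro step also reads the same on both chain lengths, but this shows only that neither change moves the number much on these four compounds, not that either change would stay this small on a different core or at a different place: the same change on two cores in this assay, a 1.1-fold higher number (0.04 log units; within the scatter) from compound 1 to compound 3 and a 1.3-fold lower number (0.11 log units; within the scatter) from compound 2 to compound 4, 1.4-fold (0.15 log units) apart, within the scatter of two such steps.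

Every step here lies within the scatter. The four compounds show where the number stays put and not what would make it move. Still open, as far as these compounds go, is whether a much longer or a shorter chain, a carboxylic acid in place of the hydroxamic acid, or a group such as trifluoromethyl or an amine in place of the chloro or methoxy would shift the number beyond that scatter.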